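The source may hold more compounds than are shown below. What is called first, only, known or untested is meant among the compounds shown, and "the series" means these compounds.

Measured so far:
Compound 1 `c1ccc2c(c1)CCC2NC1CCN(CCCc2c[nH]c3ccc(-n4cnnc4)cc23)CC1` — 280 nM
Compound 2 `CC(C)=CCN(C)C1CCN(CCCc2c[nH]c3ccc(-n4cnnc4)cc23)CC1` — 41 nM

In an assay on CHO cells for displacement of a labelled ligand from 5-hydroxytryptamine receptor 1B (Homo sapiens) (a higher number here means a weaker inhibitor, a lower number a stronger inhibitor), compound 2 gives the lowest of the two numbers, with compound 1 the nearest. Compound 3 `c1ccc2c(c1)CCC2NCC1CCN(CCCc2c[nH]c3ccc(-n4cnnc4)cc23)CC1` differs from compound 2 in one place: ((2,3-dihydro-1H-inden-1-yl)amino)methyl in place of methyl(3-methylbut-2-en-1-yl)amino on a saturated ring carbon. Within the data shown here, the only step that bears on this change is the reverse one, a 6.8-fold lower number from compound 1 to compound 2 (0.83 log units; beyond the scatter); compound 3 undoes that substitution and adds one carbon of chain. The expected outcome is a step of about the same size in the opposite direction, a 6.1-fold higher number from compound 2 to compound 3 (0.79 log units; beyond the scatter), so compound 3 is estimated at 250 nM, with a likely range from 80 nM to 800 nM.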

Compound 3, half-maximal inhibitory concentration: 25 nM
For compound 3 the middle estimate is 10-fold (1.00 log units) above the measured one, outside the stated range (below it).
By their numbers in this assay, from the lowest: compounds 3 and 2 (each within the scatter of the next); then compound 1.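

In this assay, adding one carbon to the (2,3-dihydro-1H-inden-1-yl)amino group, as ((2,3-dihydro-1H-inden-1-yl)amino)methyl on the saturated ring carbon, gives an 11-fold lower number from compound 1 to compound 3 (1.05 log units; beyond the scatter). The bulkier ring-bearing group is therefore compatible with this position, since a 1.6-fold lower number from compound 2 to compound 3 (0.21 log units; within the scatter) leaves it level with the open-chain methyl(3-methylbut-2-en-1-yl)amino group. No measurement at hand explains this result. The compounds shown leave open whether methyl(3-methylbut-2-en-1-yl)aminomethyl would respond to the added carbon in the same way, and whether a longer chain carrying the (2,3-dihydro-1H-inden-1-yl)amino group would hold this level.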